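The source may hold more compounds than are shown below. What is called first, only, known or untested is meant among the compounds shown, and "the series" means these compounds.

Series notes. Compound 1 `COCC1=CS(=O)(=O)c2ccccc2C1=O` carries a methoxymethyl group on the shared core; in a functional assay on the whole organism for inhibition, with Mus musculus as the target, at a dose of 10 mg/kg (on this read-out lower numbers stand for less inhibition and higher numbers for more inhibition at the one dose given (going by the name of the read-out)), compound 1 gives 99.9%. Compound 2 `CCOCC1=CS(=O)(=O)c2ccccc2C1=O` differs by methyl in place of hydrogen on a saturated chain carbon bound to an oxygen on a saturated carbon, and in this assay compound 2 gives 92.4%, a step of a number 7.5 percentage points lower from compound 1 to compound 2 (within the scatter). Compound 3 `CC(=O)OCC1=CS(=O)(=O)c2ccccc2C1=O` differs from compound 1 by acetyl in place of methyl on an oxygen on a saturated carbon; in this assay compound 3 gives 99.5%.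

Compound 4 `CCC(=O)OCC1=CS(=O)(=O)c2ccccc2C1=O` is not yet measured. Relative to compound 3 it carries methyl in place of hydrogen on a saturated chain carbon bound to a carbonyl carbon. This is the same kind of change as that from compound 1 to compound 2, but its place differs: there the carbon is bound to an oxygen on a saturated carbon, here to a carbonyl carbon. A step of about a number 4.5 percentage points lower from compound 3 to compound 4 (within the scatter) is expected for compound 4, because the earlier step of a number 7.5 percentage points lower from compound 1 to compound 2 (within the scatter) stayed within the scatter. Compound 4 is estimated at 95% in this assay.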

Compound 4, a percentage reported as inhibition, in the whole organism at one dose (the size of the read-out at that dose, not a potency): 99.5%
For compound 4 the middle estimate is 4.5 percentage points below the measured one, within the range that was stated.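

In this assay, methyl in place of hydrogen gives no change at the digits printed from compound 3 to compound 4 (within the scatter), while propanoyl on the oxygen gives a number 7.1 percentage points higher from compound 2 to compound 4 (within the scatter) and a number 0.4 percentage points lower from compound 1 to compound 4 (within the scatter). Set beside the earlier step, the change carries from one core to the other without a difference that can be told apart: the same change on two cores in this assay, a number 7.5 percentage points lower (within the scatter) from compound 1 to compound 2 and no change at the digits printed (within the scatter) from compound 3 to compound 4, 7.5 percentage points apart, within the scatter of two such steps. This shows agreement for these two pairs only; with both steps inside the scatter, it does not show that the change has any real effect on either core, nor does it give a size that could be carried to another compound.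

Still open, going by these compounds, is how this assay would read with a chain longer than propanoyl on that oxygen. On these data alone, an amine or a carboxylic acid in that place is equally open.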